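The source may report more compounds than this note shows. Statements on the series, on what has been measured and on what is new or still open speak of the compounds shown alone.

Of the compounds shown here, two of a shared core have been measured in a functional assay on HT-29 cells (Homo sapiens) for cytotoxicity, read by MTT assay, with a stated time of 24 h, tested at 16 ug/mL; on this read-out higher numbers stand for a stronger effect at the one concentration tested and lower numbers for a weaker effect. Compound 1 `Cc1nnc(SCC(=O)Nc2ccc(-c3nc(-c4ccccc4)c(-c4ccccc4)n3C)cc2)s1` gives 83.3% in that assay, while compound 2 `CCN1CCN(CC(=O)Nc2ccc(-c3nc(-c4ccccc4)c(-c4ccccc4)n3C)cc2)CC1` gives 28.4%. Among the measured compounds shown here, on these two numbers compound 2 stands lowest, and the step to its only neighbour is large: a number 54.9 percentage points lower from compound 1 to compound 2 (beyond the scatter), with compound 2 at the bottom.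

Compound 3 `Cn1c(-c2ccc(NC(=O)CN3CCN(Cc4ccc(Cl)cc4)CC3)cc2)nc(-c2ccccc2)c1-c1ccccc1` differs from compound 2 in one place: 4-chlorophenyl in place of methyl on a saturated chain carbon bound to an amine nitrogen in a ring. For the measured compounds named here, the one measured step, from compound 1 to compound 2, alters the group on the saturated chain carbon bound to the carbonyl carbon, not the carbon bound to the ring amine nitrogen, so no measured step bears directly on this change. That step shows only that the side chain of the shared core can move the number in this assay by a large amount. For a methyl-to-4-chlorophenyl swap on the ring amine side, no direction can be read from the data, and the estimate for compound 3 must carry a wide range. Compound 3 is expected to give 45%, between 15% and 80%, which would mean an expected step of a number 16.6 percentage points higher from compound 2 to compound 3 (beyond the scatter).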

Compound 3, a percentage reported as activity, at one concentration (the size of the read-out at that concentration, not a potency): 52.9%
For compound 3 the middle estimate is 7.9 percentage points below the measured one, within the range that was stated.
By their numbers in this assay, from the lowest: compound 2; then compound 3; then compound 1.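

In this assay the change of methyl to 4-chlorophenyl on a saturated chain carbon bound to an amine nitrogen in a ring, which can also be read as ethyl to 4-chlorobenzyl, gives a number 24.5 percentage points higher from compound 2 to compound 3 (beyond the scatter) and counts as a modest step. Among the compounds shown here, this is the first measured change at this place, so it shows that the number responds here too, and not only to the swap on the saturated chain carbon bound to a carbonyl carbon, which gave a number 54.9 percentage points lower from compound 1 to compound 2 (beyond the scatter) and counts as a large step. Nothing available bears on the reason for the new step.

The change brings in an aromatic ring and a chlorine together, so these two compounds cannot separate what each contributes, and a plain benzyl group, with hydrogen in place of the chlorine, would speak to that. Also open, going by these compounds, is how a 4-fluorobenzyl or a phenethyl group would read at this place, and with a single concentration these numbers say nothing about potency.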